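The compounds below may be only part of what the source reports. "The series", "measured", "known", "first", "only" and "open" are said of these compounds alone.

Compound 3 `Brc1cccc2c1nnn2CC1CCCC1` stands at the top of the two numbers available in an ADME assay on microsomes from liver (Rattus norvegicus, strain Wistar) for metabolic stability, tested at 2.5 uM; a higher number here means faster removal of the compound, a lower number slower removal: compound 3 gives 14.6 mL/min/g, the highest value among the measured entries. Compound 1 `Fc1cc(C(F)(F)F)ccc1-c1ccc(Cn2nnc3ccccc32)cc1` lies far beneath it, with compound 1 giving 0.4 mL/min/g in this assay, a gap that is well beyond the usual scatter. Compound 2 `Brc1ccc(Cn2nnc3c(Br)cccc32)cn1` is also part of the set, but in this assay compound 2 gives "not determined" (no result reported), so it offers no number for comparison.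

The step from compound 3 leads to compound 4 `CC(C)Cn1nnc2c(Br)cccc21`. The change is isopropyl in place of cyclopentyl on a saturated chain carbon bound to an aromatic nitrogen. Going by the values given here, no measured pair with a comparable change exists in this set, so the size of the step must be estimated from compound 3 alone. Since compound 3 already sits at the highest value, the expectation is that the step from compound 3 to compound 4 is modest, most likely within the scatter, with a slight lean toward slower removal: the expected step is a 1.5-fold lower number from compound 3 to compound 4 (0.16 log units; within the scatter). Compound 4 is therefore estimated at 10 mL/min/g, with a range from 4 mL/min/g to 25 mL/min/g.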

Compound 4, intrinsic clearance in a liver preparation (reported as CLH), per the amount of preparation that the assay uses: 4 mL/min/g
Compound 4: the middle estimate sits 2.5-fold (0.40 log units) above what was measured, and the stated range covers the measured number.
By their numbers in this assay, from the lowest: compound 1; then compound 4; then compound 3.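

In this assay, going by these compounds alone, the group at this place, on a saturated chain carbon bound to an aromatic nitrogen, proves able to shift the number: isopropyl in place of cyclopentyl gives a 3.7-fold lower number from compound 3 to compound 4 (0.56 log units; beyond the scatter) and provides the first comparison in the set between compounds that differ in one place. The change removes the ring and goes from the count of five heavy atoms to three, and the number falls beyond the scatter. This single pair cannot separate the loss of the ring from the loss of heavy atoms, and nothing available gives a reason for the step.

On these data alone, whether a longer open chain, a cyclobutyl ring or an amine at this place would lower the number further remains open. As far as these compounds go, it is equally open whether the same change would give a similar step on a different core.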